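Hydroxy to Amino on the Carbonyl-Side Ring: Compound 3

A few compounds are considered here, and "the series" means these few. Any claim that something is new, unique, unknown or untested is made for them only; others in the source may bear on it.

For the measured compounds named here, two measured compounds share one core and differ only in the single group carried on the aromatic ring next to the carbonyl. Compound 1 `O=C(/C=C/c1ccc2c(c1)B(O)OC2)c1ccc(Cl)cc1` carries chloro there, and in a functional assay on SK-OV-3 cells (Homo sapiens) for cytotoxicity, read by MTT assay, with a stated time of 48 h (a higher number here means a weaker inhibitor, a lower number a stronger inhibitor), compound 1 gives 3700 nM. Going by the values given here, compound 2 `O=C(/C=C/c1ccc2c(c1)B(O)OC2)c1ccc(O)cc1` carries hydroxy in the same place, and in this assay compound 2 gives 13000 nM, the higher of the two numbers known so far, so compound 2 is the weaker of the pair; the exchange shows as a 3.5-fold higher number from compound 1 to compound 2 (0.55 log units; beyond the scatter), a modest step. Compound 3 `Nc1ccc(C(=O)/C=C/c2ccc3c(c2)B(O)OC3)cc1` continues from compound 2 with a further small exchange: amino in place of hydroxy on an aromatic carbon. Among the compounds with values here, no measured step swaps hydroxy for amino. Within the data shown here, the one measured step concerns chloro against hydroxy and was modest, and it gives no direction for amino. Since the group that leaves and the group that enters match in size and in donor and acceptor count, no step beyond the scatter is expected in this assay. The estimate for compound 3 is therefore 11000 nM, with a range from 3500 nM to 35000 nM, which means an expected step of a 1.2-fold lower number from compound 2 to compound 3 (0.07 log units; within the scatter).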

Compound 3, half-maximal inhibitory concentration: 20200 nM
Estimate against measurement, compound 3: 1.8-fold (0.26 log units) below, within the range that was stated.
By their numbers in this assay, from the lowest: compound 1; then compounds 2 and 3 (each within the scatter of the next).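

Within this assay the exchange of hydroxy for amino at this place, para to a large group, gives a 1.6-fold higher number from compound 2 to compound 3 (0.19 log units; within the scatter) and so leaves the pair inside the usual scatter, which means two groups that match in size and in donor and acceptor count cannot be told apart here. Chloro can now be set against two different groups on the same aromatic carbon, with a 3.5-fold higher number from compound 1 to compound 2 (0.55 log units; beyond the scatter) and a 5.5-fold higher number from compound 1 to compound 3 (0.74 log units; beyond the scatter) both beyond the scatter, so compound 1 is the strongest of these three and neither replacement comes close to it. Nothing measured alongside these numbers tells what lies behind this order.

Going by these compounds, whether the lower number belongs to chloro alone, or would also appear with fluoro, bromo, methyl or methoxy on this carbon, remains open. On these data alone, how a carboxylic acid or a longer chain would fare here is equally open, and so is whether the same order of groups would hold on a different core or in other cells.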